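Adding a Sulfanyl Group to Compound 2

This account rests on a few compounds, and the source may have more. Where it says the series, first, only, none or still open, it means among the compounds named here.

- compound 1 `O=C(Nc1nc2ccccc2s1)c1ccc(OC(F)F)c(OCC2CC2)c1`: 36.4%
- compound 2 `O=C(Nc1ccc2ncsc2c1)c1ccc(OC(F)F)c(OCC2CC2)c1`: 36.8%

In an ADME assay on S9 fraction from liver (Rattus norvegicus, strain Wistar) for metabolic stability, read by HPLC, using NADPH, tested at 20 uM (on this read-out higher numbers stand for a more stable compound and lower numbers for a less stable compound), compound 2 gives 36.8% and compound 1 gives 36.4%, so the two lie within the usual scatter of each other. The next structure, compound 3 `O=C(Nc1ccc2nc(S)sc2c1)c1ccc(OC(F)F)c(OCC2CC2)c1`, has sulfanyl in place of hydrogen on an aromatic carbon of compound 2: sulfanyl in place of hydrogen on an aromatic carbon.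

Among the compounds with values here, only one measured step exists, a number 0.4 percentage points higher from compound 1 to compound 2 (within the scatter). It swaps 1,3-benzothiazol-2-yl for 1,3-benzothiazol-6-yl on an amide-type nitrogen, so it offers only indirect guidance. Within the data shown here, no measured compound carries a sulfanyl, and the data therefore give no direction for this change. The expected result is no shift beyond the scatter, with wide uncertainty. The estimated change is a number 3.8 percentage points lower from compound 2 to compound 3 (within the scatter). For compound 3 the estimated value is 33%, with an expected range from 15% to 52%.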

Compound 3, percent of the compound remaining: 84.2%
The estimate for compound 3 lay 51.2 percentage points below the measured number; the whole stated range lies below it.
By their numbers in this assay, from the lowest: compounds 1 and 2 (each within the scatter of the next); then compound 3.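

Placing sulfanyl on the aromatic carbon of the five-membered ring, next to the ring nitrogen and next to the ring sulfur, gives a number 47.4 percentage points higher from compound 2 to compound 3 (beyond the scatter) in this assay and lifts compound 3 clear of the other two compounds. The step from compound 1 to compound 2 changed where the benzothiazole joins the amide nitrogen and stayed within the scatter, whereas this step shows that the read-out can respond strongly to a small change at this one ring carbon. Nothing measured here explains the rise.

From the compounds shown here alone, whether a methyl, a methylthio group or an amine on this same carbon would raise the number as well remains open, so the gain cannot yet be tied to sulfanyl alone. Also open, going by these compounds, is whether the gain would hold with a longer chain in place of the cyclopropylmethoxy group.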